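Bromo in place of fluoro in compound 4

A few compounds are considered here, and "the series" means these few. Any claim that something is new, unique, unknown or untested is made for them only; others in the source may bear on it.

Measured so far in a physicochemical assay, with a stated time of 30 min; on this read-out higher numbers stand for weaker inhibition and lower numbers for stronger inhibition:

compound 1 `COc1cc2c(cc1OC)C(=O)C(C(=O)Nc1ccc(Br)cc1)C2` gives 72.1 ug/mL
compound 2 `COc1ccccc1NC(=O)C1Cc2cc(OC)c(OC)cc2C1=O` gives 45.8 ug/mL
compound 3 `COc1cc2c(cc1OC)C(=O)C(C(=O)Nc1ccccc1F)C2` gives 75.7 ug/mL

Compound 3 (75.7 ug/mL) lies within the scatter of both other compounds, so the numbers set it clearly apart from neither. The next compound, compound 4 `COc1cc2c(cc1OC)C(=O)C(C(=O)Nc1ccccc1Br)C2`, differs from it by a single change: bromo in place of fluoro on an aromatic carbon. Among the measured compounds shown here, no measured step makes this exact swap, so the evidence is indirect. Fluoro in place of methoxy on an aromatic carbon gave a 1.7-fold higher number from compound 2 to compound 3 (0.22 log units; within the scatter) and is the closest comparison. Replacing 4-bromophenyl with 2-fluorophenyl gave a 1.0-fold higher number from compound 1 to compound 3 (0.02 log units; within the scatter) while replacing it with 2-methoxyphenyl gave a 1.6-fold lower number from compound 1 to compound 2 (0.20 log units; within the scatter) in the same series. All three steps stay within the scatter, and compound 1 (72.1 ug/mL) shows that a bromo-bearing member of the series falls inside the same narrow band. No step beyond the scatter is therefore expected in this assay, and the data favour no direction. The expected change is small, namely a 1.1-fold lower number from compound 3 to compound 4 (0.06 log units; within the scatter) as estimated here. For compound 4 the estimate is 66 ug/mL with an expected range from 38 ug/mL to 112 ug/mL around it.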

Compound 4, half-maximal inhibitory concentration: 65.4 ug/mL
Compound 4: the middle estimate sits 1.0-fold (0.00 log units) above what was measured; the measured number falls inside the stated range.
By their numbers in this assay, from the lowest: compounds 2, 4, 1 and 3 (each within the scatter of the next).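

In this assay, the direct exchange of one halogen for another on this aromatic carbon, ortho to a large group, gave a 1.2-fold lower number from compound 3 to compound 4 (0.06 log units; within the scatter), so the change from fluoro to bromo at this place stays within the scatter. The same place also tolerates a wider exchange: bromo in place of methoxy gave a 1.4-fold higher number from compound 2 to compound 4 (0.15 log units; within the scatter), and 2-bromophenyl in place of 4-bromophenyl on the amide-type nitrogen gave a 1.1-fold lower number from compound 1 to compound 4 (0.04 log units; within the scatter), so the three new steps all stay within the scatter, and neither the identity of this group nor the place of the bromo separates these four compounds. Nothing among the available data explains why these steps are so small.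

The compounds shown leave open whether any group at this place could move the number beyond the scatter, since an amine, a carboxylic acid or a trifluoromethyl group stands there in none of them. They also leave open whether a change elsewhere, such as a methyl group on the amide nitrogen or a longer chain in place of the phenyl ring, would do so.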